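The source may report more compounds than this note shows. Statements on the series, on what has been measured and on what is new or still open speak of the compounds shown alone.

Measured compounds:
- compound 1, `COc1c(N2CC[C@@H](CO)C2)c(F)cc2c(=O)c(C(=O)O)cn(Cc3ccc(-c4ccccc4)cc3)c12`: in an assay on isolated protein for inhibition of DNA topoisomerase 1 (Homo sapiens), with a stated time of 15 min (a lower number here means a stronger inhibitor, a higher number a weaker inhibitor), compound 1 gives > 200000 nM
- compound 2, `CNC(=O)c1cn(Cc2ccc(-c3ccccc3)cc2)c2c(OC)c(N3CC[C@@H](CN)C3)c(F)cc2c1=O`: compound 2 gives 82100 nM
- compound 3, `O=C(O)c1cn(Cc2ccc(-c3ccccc3)cc2)c2cc(N3CC4CNCC4C3)c(F)cc2c1=O`: compound 3 gives 33300 nM

The value of compound 1 is a limit of this assay, not a number. Among the two numbers, compound 3 has the lower one; compound 2 sits higher by a margin beyond the scatter of this assay. Going by the values given here, no pair of these three differs in a single place, so no single step can be read off. Compound 2 carries the 3-(aminomethyl)pyrrolidin-1-yl group together with other changes on the shared core, which leaves the contribution of that group alone open.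

Compound 4, `NC[C@@H]1CCN(c2cc3c(cc2F)c(=O)c(C(=O)O)cn3Cc2ccc(-c3ccccc3)cc2)C1`, is not yet measured. It differs from compound 3 in one place: a group of 7 heavy atoms (5 carbon, 2 nitrogen; one five-membered non-aromatic ring with 1 hetero atom) in place of a group of 8 heavy atoms (6 carbon, 2 nitrogen; 2 five-membered non-aromatic rings with 1 hetero atom each), on an aromatic carbon – a group of 7 heavy atoms (5 carbon, 2 nitrogen; one five-membered non-aromatic ring with 1 hetero atom) in place of a group of 8 heavy atoms (6 carbon, 2 nitrogen; 2 five-membered non-aromatic rings with 1 hetero atom each), on an aromatic carbon.

Among the compounds with values here, with no measured step of this kind at hand, the expectation for compound 4 is a modest move in this assay, most likely to a somewhat higher number, with the step from compound 3 to compound 4 estimated at a 1.4-fold higher number from compound 3 to compound 4 (0.13 log units; within the scatter). Compound 4 is therefore estimated at 45000 nM, expected between 15000 nM and 130000 nM.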

Compound 4, half-maximal inhibitory concentration: 15600 nM
For compound 4 the middle estimate is 2.9-fold (0.46 log units) above the measured one; measured number inside the range.
By their numbers in this assay, from the lowest: compound 4; then compound 3; then compound 2. At a limit, above all of these: compound 1.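

Working notes on the aromatic carbon ortho to the fluoro group: in this assay, 3-(aminomethyl)pyrrolidin-1-yl in place of the group with two five-membered non-aromatic rings gives a 2.1-fold lower number from compound 3 to compound 4 (0.33 log units; beyond the scatter). Going by these compounds alone, this is the first change that can be read in one place, and it shows that the number responds to the group at this carbon, even though both groups have the same counts of hydrogen-bond donors and acceptors and differ by a single heavy atom. Compound 2 carries the same 3-(aminomethyl)pyrrolidin-1-yl group alongside other changes and could not show this, and nothing given here bears on the cause of the step.

Still open, as far as these compounds go, is whether a piperazine, an open-chain aminoalkyl amine or the mirror-image form of the aminomethyl pyrrolidine at this carbon would move the number further. Also open, from the compounds shown here alone, is whether the same step would hold on a core carrying the methoxy group or the N-methyl amide found in compound 2.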